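Compound 1 to compound 4: a bromofuran in place of pyrrole

The source may report more compounds than this note shows. Statements on the series, on what has been measured and on what is new or still open speak of the compounds shown alone.

Compound 1 `COc1ccc(CNC(=O)/C(C#N)=C/c2ccc[nH]2)cc1` is tested in a functional assay on NCI-H460 cells (Homo sapiens) for inhibition, read by MTT assay, with a stated time of 72 h (a higher number here means a weaker inhibitor of growth, a lower number a stronger inhibitor of growth), and gives > 50000 nM, which is a limit of the assay and not a number. Compound 2 `N#C/C(=C\c1ccc[nH]1)C(=O)NCc1ccc(Cl)c(Cl)c1` gives > 50000 nM in this assay, again a limit. Compound 3 `N#C/C(=C\c1ccco1)C(=O)NCc1ccc(Cl)c(Cl)c1` gives > 50000 nM, also a limit. The three values therefore all sit at the same limit (the limit of > 50000 nM in this assay, at which 3 of the 3 values shown sit), so compound 1 stands nowhere apart from the other two; none of them can be ordered against another.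

Compound 4 `COc1ccc(CNC(=O)/C(C#N)=C/c2cc(Br)co2)cc1` differs from compound 1 by 4-bromofuran-2-yl in place of 1H-pyrrol-2-yl on a double-bonded chain carbon bound to a double-bonded chain carbon. Within the data shown here, the only measured step that touches a related change, a step that the two limits leave unreadable from compound 2 to compound 3, runs between two limits and its size cannot be read. No step beyond the scatter can be foreseen in either direction from what is shown.

Compound 4 is therefore estimated to give 50000 nM, with a range from 15000 nM to 200000 nM. The step this estimate means, a number no higher from compound 1 to compound 4 (the limit leaves the size open), is expected to be none that two limits could reveal.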

Compound 4, concentration for 50% growth inhibition: > 100000 nM
Compound 4: no number, only a limit; the forecaster's own chance of this, stated with the estimate: 80%; middle value at least 2.0-fold (0.30 log units) away from the limit.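

In this assay compound 4 gives > 100000 nM, a limit of the assay and not a number. Among these compounds, compound 1 also stands at a limit, and no step from compound 1 to compound 4 can be read. The compounds shown leave open how 4-bromofuran-2-yl compares with 1H-pyrrol-2-yl in growth inhibition.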